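This account rests on a few compounds, and the source may have more. Where it says the series, first, only, none or still open, it means among the compounds named here.

Measured so far:
compound 1, `COc1ccccc1N1CCN(CCCNc2ccc(C(=O)N(C)C)cn2)CC1`: 25.1 nM
compound 2, `CN(C)C(=O)c1cccnc1NCCCN1CCN(c2ccccc2C#N)CC1`: 2 nM

Both compounds were tested in a functional assay for antagonist activity at Alpha-1A adrenergic receptor (Oryctolagus cuniculus) (a lower number here means tighter binding, a higher number weaker binding), and compound 2 gives the lowest of the two numbers, with compound 1 standing a good deal higher, a gap that lies beyond the usual scatter. The two share the same core; they differ only in the small group carried on the aromatic ring attached to the piperazine.

The next compound, compound 3 `CN(C)C(=O)c1cccnc1NCCCN1CCN(c2ccccc2Cc2ccccc2)CC1`, keeps the core of compound 2 and changes that same position: benzyl in place of cyano on an aromatic carbon. The group that enters is far larger than the one it replaces and sits ortho to a large group, so the shape of that end of the molecule changes considerably. Going by the values given here, no pair of measured compounds shows a change of this kind, so there is nothing to lean on for its size. The expectation is a moderate loss of binding, with the step from compound 2 to compound 3 estimated as a 7.5-fold higher number from compound 2 to compound 3 (0.88 log units; beyond the scatter). For compound 3 in this assay the estimate is 15 nM, within a range of 3 nM to 80 nM.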

Compound 3, dissociation constant: 6.31 nM
Compound 3: middle estimate off by 2.4-fold (0.38 log units), on the high side; the measured number falls inside the stated range.
By their numbers in this assay, from the lowest: compound 2; then compound 3; then compound 1.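

In this assay, the aromatic carbon ortho to a large group accepts a far bigger substituent with only a modest penalty: benzyl in place of cyano gives a 3.2-fold higher number from compound 2 to compound 3 (0.50 log units; beyond the scatter). The change goes from 2 heavy atoms to 7 and adds a whole six-membered aromatic ring, yet compound 3 still gives 6.31 nM and so remains a tight binder, even though the hydrogen-bond acceptor of the cyano group is gone. Nothing available explains why the step has this size, so the result describes what this place tolerates, not the reason for it.

On these data alone, because only cyano and benzyl can be compared directly here, it remains open how small groups such as methyl or a chlorine atom would behave at this place, or whether a longer chain such as phenylethyl, or an amine or carboxylic acid, would be accepted as well. It is also unknown whether benzyl would be tolerated to a similar degree on the core of compound 1, where the dimethylamide sits elsewhere on the shared ring.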